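Compound 3: methylsulfanyl in place of ethoxy

This account rests on a few compounds, and the source may have more. Where it says the series, first, only, none or still open, it means among the compounds named here.

In a functional assay on MCF7 cells (Homo sapiens) for inhibition, read by resazurin assay, with a stated time of 72 h (on this read-out lower numbers stand for stronger inhibition and higher numbers for weaker inhibition), compound 2 (`CCOc1ccc(C2C(O)C(=O)N2c2cc(OC)c(OC)c(OC)c2)cc1`) gives 7 nM and compound 1 (`CCSc1ccc(C2C(O)C(=O)N2c2cc(OC)c(OC)c(OC)c2)cc1`) gives 6 nM, so the two stand level within the scatter.

Compound 3 (`COc1cc(N2C(=O)C(O)C2c2ccc(SC)cc2)cc(OC)c1OC`) carries methylsulfanyl in place of ethoxy on an aromatic carbon, para to a large group: methylsulfanyl in place of ethoxy on an aromatic carbon.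

Among the measured compounds shown here, one measured step bears on this change. Going from ethylsulfanyl to ethoxy at the same place gave a 1.2-fold higher number from compound 1 to compound 2 (0.07 log units; within the scatter), so exchanging sulfur and oxygen there made no visible difference in this pair. For the measured compounds named here, no measured step covers the shorter chain, so that part of the change is untested, and the support is thin.

In this assay no step beyond the scatter is therefore expected. The estimated step is no change at the digits printed from compound 2 to compound 3 (within the scatter). For compound 3 the expected value is 7 nM, with an estimated range of 3 nM to 18 nM.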

Compound 3, half-maximal inhibitory concentration: 5 nM
Compound 3: middle estimate off by 1.4-fold (0.15 log units), on the high side; the measured number falls inside the stated range.
By their numbers in this assay, from the lowest: compounds 3, 1 and 2 (each within the scatter of the next).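

In this assay, the sulfur chain can now be read on its own: hydrogen in place of methyl on the chain carbon bound to sulfur gives a 1.2-fold lower number from compound 1 to compound 3 (0.08 log units; within the scatter), so the chain length untested until now shows no visible effect between these two groups. The direct exchange of methylsulfanyl for ethoxy gives a 1.4-fold lower number from compound 2 to compound 3 (0.15 log units; within the scatter), so this combined change in atom and chain also stays level at this position, para to a large group. No other measurement bears on why these compounds stand level.

The compounds shown leave open whether this position stays as flat with a group of another kind, such as an amine, a carboxylic acid or a longer chain like butoxy. All three stand level, so no limit on what the position accepts has yet appeared.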